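The source may report more compounds than this note shows. Statements on the series, on what has been measured and on what is new or still open speak of the compounds shown alone.

Measured so far in a functional assay on BMDM cells (Mus musculus, strain C57BL/6) for inhibition, with a stated time of 2 days; a lower number here means a stronger inhibitor, a higher number a weaker inhibitor:

Compound 1 `CCOC(=O)c1sc(NC(=O)Cn2cc(-c3cccs3)nn2)nc1C`: 20 nM
Compound 2 `Cc1cc(NC(=O)Cn2cc(-c3ccc(Cl)cc3)nn2)no1`: 1910 nM
Compound 3 `Nc1cccc(-c2cn(CC(=O)Nc3nc4ccccc4s3)nn2)c1`: 1110 nM

Compound 1 gives the lowest number of the three in this assay; compound 3 and compound 2 both lie beyond the scatter above it, compound 2 furthest. Compound 4 `CCOC(=O)c1sc(NC(=O)Cn2cc(-c3ccc([N+](=O)[O-])cc3)nn2)nc1C` has not been measured. It differs from compound 1 in one place: 4-nitrophenyl in place of thiophen-2-yl on an aromatic carbon. Going by the values given here, no pair of measured compounds differs in only one place, so no step of this kind has been seen; compound 2 and compound 3 rest on other cores, and their values show only where those cores stand. The step from compound 1 is expected to be a modest loss, a 3.0-fold higher number from compound 1 to compound 4 (0.48 log units; beyond the scatter), of a size that may not clear the scatter. Compound 4 is estimated at 60 nM, in the range 15 nM to 300 nM.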

Compound 4, half-maximal inhibitory concentration: 1840 nM
For compound 4 the middle estimate is 31-fold (1.49 log units) below the measured one; measured number outside the range, above it.
By their numbers in this assay, from the lowest: compound 1; then compounds 3, 4 and 2 (each within the scatter of the next).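

Going by these compounds alone, on the core of compound 1, the aromatic carbon of the five-membered aromatic ring with 3 nitrogen proves sensitive to its substituent in this assay: 4-nitrophenyl in place of thiophen-2-yl gives a 92-fold higher number from compound 1 to compound 4 (1.96 log units; beyond the scatter), the first single-place change. Aromatic groups are therefore not interchangeable at this position. Nothing at hand explains the loss.

The compounds shown leave open whether the loss follows the nitro group or the six-membered ring itself. Plain phenyl or furan-2-yl at this position would help separate the two.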